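Methoxy to methyl on a weakly active aortic urea

The source may hold more compounds than are shown below. What is called first, only, known or untested is meant among the compounds shown, and "the series" means these compounds.

Compound 1 `COc1ccc(NC(=O)NC2CC(C)(C)Oc3ccc(F)cc32)cc1` gives 15500 nM in a functional assay (aorta) with Rattus norvegicus as the target; a lower number here means that less compound is needed, a higher number that more compound is needed for the effect. Compound 2 `COc1ccc(NC(=O)NC2CC(C)(C)Oc3ccc(Br)cc32)cc1` gives > 10000 nM in this assay, which is a limit of the assay and not a number. The step that the limit leaves unreadable from compound 1 to compound 2 therefore cannot be read in size, as the limit of > 10000 nM in this assay, at which 1 of the 2 values shown sits, shows. Compound 3 `Cc1ccc(NC(=O)NC2CC(C)(C)Oc3ccc(Br)cc32)cc1` differs from compound 2 by methyl in place of methoxy on an aromatic carbon. Going by the values given here, no measured step touches this change, and compound 2 itself stands only at a limit. For compound 3 the expected step that the limit leaves unreadable from compound 2 to compound 3 is accordingly none beyond the scatter. Compound 3 is estimated at 15000 nM in this assay, with a range from 5000 nM to 50000 nM.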

Compound 3, half-maximal effective concentration: > 30000 nM
Compound 3: only a limit was reported; the forecaster's own chance of this, stated with the estimate: 60%; middle value at least 2.0-fold (0.30 log units) away from the limit.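

In this assay compound 3 gives > 30000 nM, which is a limit of the assay and not a number. Going by these compounds alone, compound 2 also stands only at a limit, so no step between compound 2 and compound 3 can be read. On these data alone, whether methyl in place of methoxy changes the effect at all stays open.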